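Oxygen for Sulfur in a Weakly Active Bicyclic Amide

The compounds below may be only part of what the source reports. "The series", "measured", "known", "first", "only" and "open" are said of these compounds alone.

Measured compounds:
compound 1 `O=C(NCc1ccc(S(=O)(=O)N2CCCCC2)cc1)c1cc2cnccc2s1` gives 1600 nM
compound 2 `O=C(NCc1ccc(S(=O)(=O)N2CCCCC2)cc1)c1cc2cnccc2o1` gives 1500 nM
compound 3 `O=C(NCc1ccc(S(=O)(=O)N2CCCCC2)cc1)c1cc2cccnc2s1` gives > 10000 nM

In a functional assay on A2780 cells (Homo sapiens) for inhibition, read by sulforhodamine B assay, with a stated time of 72 h (on this read-out lower numbers stand for stronger inhibition and higher numbers for weaker inhibition), compound 3 stands at the weak end of the series: its value is a limit of the assay and not a number, the same limit that the limit of > 10000 nM in this assay, at which 1 of the 3 values shown sits, describes. Compound 1 and compound 2 both give numbers, and the steps of an at least 6.2-fold higher number from compound 1 to compound 3 (0.79 log units; beyond the scatter) and an at least 6.6-fold higher number from compound 2 to compound 3 (0.82 log units; beyond the scatter) are each beyond the scatter, so compound 3 is the least potent of the three on these data.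

Compound 4 `O=C(NCc1ccc(S(=O)(=O)N2CCCCC2)cc1)c1cc2ccncc2o1` is the next compound to be measured. The change from compound 3 to compound 4 is a group of 9 heavy atoms (7 carbon, 1 nitrogen, 1 oxygen; one five-membered aromatic ring with 1 hetero atom, one six-membered aromatic ring with 1 hetero atom) in place of a group of 9 heavy atoms (7 carbon, 1 nitrogen, 1 sulfur; one five-membered aromatic ring with 1 hetero atom, one six-membered aromatic ring with 1 hetero atom), on a carbonyl carbon. Among the measured compounds shown here, the one measured step of the same kind is a 1.1-fold lower number from compound 1 to compound 2 (0.03 log units; within the scatter), which lies within the scatter, so swapping sulfur for oxygen in this position of the bicyclic group left the number essentially unchanged there.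

On that basis the step is expected to be small, a step that the limit leaves unreadable from compound 3 to compound 4, with no direction beyond the scatter. Compound 4 is therefore estimated at 12000 nM, with a range from 4000 nM to 40000 nM, and it is likely that the assay again reports only a limit.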

Compound 4, half-maximal inhibitory concentration: 29 nM
Beside the measured number, compound 4's estimate is 410-fold (2.62 log units) above it; measured number outside the range, below it.
By their numbers in this assay, from the lowest: compound 4; then compounds 2 and 1 (each within the scatter of the next). At a limit, above all of these: compound 3.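

In this assay, the step of a 52-fold lower number from compound 2 to compound 4 (1.71 log units; beyond the scatter) shows that the bicyclic group on the carbonyl carbon matters far more than the earlier swap of sulfur for oxygen suggested: the group that leaves and the group that enters have the same atom counts, so the arrangement of those atoms alone carries a large change. The steps of a 55-fold lower number from compound 1 to compound 4 (1.74 log units; beyond the scatter) and an at least 340-fold lower number from compound 3 to compound 4 (2.53 log units; beyond the scatter) are of the same large order, which makes compound 4 the most potent of the four and shows that the neutral swap between compound 1 and compound 2 does not describe every change at this place. Compound 3 remains at a limit of the assay, so its step gives only a minimum size: the limit of > 10000 nM in this assay, at which 1 of the 4 values shown sits.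

The compounds shown leave open whether a sulfur-containing group with the atom arrangement of compound 4 would give a similar number, so the part played by oxygen in that arrangement cannot be separated from the part played by the arrangement itself. They also leave open whether a methyl group or an amine added to the bicyclic group of compound 4 would keep its potency.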